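Oxetan-3-yl on the sulfonamide nitrogen of compound 1

This account rests on a few compounds, and the source may have more. Where it says the series, first, only, none or still open, it means among the compounds named here.

Measured so far in a physicochemical assay for lipophilicity, at pH 7.4; on this read-out higher numbers stand for higher lipophilicity and lower numbers for lower lipophilicity

- compound 1 `CCc1ccc(N(CC2CCC2)S(=O)(=O)c2ccc3c(c2)C(=O)CC(C2CCOCC2)O3)cc1` gives 4.1
- compound 2 `CC(C)CN(c1ccc(F)cc1F)S(=O)(=O)c1ccc2c(c1)C(=O)CC(C1CCOCC1)O2` gives 3.62
- compound 3 `CCc1ccc(N(CC(C)C)S(=O)(=O)c2ccc3c(c2)C(=O)CC(C2CCNCC2)O3)cc1` gives 2.21

Compound 1 stands highest of the three in this assay. Compound 2 lies lower by a gap beyond the usual scatter, and compound 3 is furthest away, also beyond the scatter.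

The next compound to be measured is compound 4 `CCc1ccc(N(C2COC2)S(=O)(=O)c2ccc3c(c2)C(=O)CC(C2CCOCC2)O3)cc1`, which carries oxetan-3-yl in place of cyclobutylmethyl on a sulfonamide nitrogen. The rest of compound 1 stays the same.

Among the measured compounds shown here, no two measured compounds differ in one place only, so the series gives no direct measure of this change. Each gap among the three values combines several structural differences. The expectation therefore rests on the counted difference alone and points to a lower number in this assay, with a step beyond the scatter. For the measured compounds named here, compound 3 (2.21) shows how low a number has been seen so far. The expected change is a number 1.20 log units lower from compound 1 to compound 4 (beyond the scatter) and remains an estimate until a measurement exists. For compound 4 the estimated value is 2.9 (expected range 2.4 to 3.4).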

Compound 4, distribution coefficient: 2.72
Beside the measured number, compound 4's estimate is 0.18 log units above it; the range from low to high includes it.
By their numbers in this assay, from the lowest: compound 3; then compound 4; then compound 2; then compound 1.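

Oxetan-3-yl in place of cyclobutylmethyl on a sulfonamide nitrogen now has a direct reading in this assay and gives a number 1.38 log units lower from compound 1 to compound 4 (beyond the scatter) with the rest of compound 1 unchanged. The gaps among compound 1, compound 2 and compound 3 each combined several structural differences, whereas this step belongs to one place alone and shows that the group on this nitrogen can by itself move the read-out by a large amount. Both groups carry a four-membered non-aromatic ring and no hydrogen-bond donor, and the counted differences are 5 heavy atoms against 4 and a ring oxygen that adds 1 hydrogen-bond acceptor, but no available measurement accounts for the size of the step.

The compounds shown leave open how much of the step goes with the ring oxygen and how much with the change in the group's size and attachment, a question that cyclobutyl or oxetan-3-ylmethyl on the same nitrogen would address. Also open, from the compounds shown here alone, is whether the same exchange gives a step of similar size on other compounds, such as compound 2.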